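The source may hold more compounds than are shown below. What is called first, only, known or untested is meant among the compounds shown, and "the series" means these compounds.

Compound 1 `O=c1[nH]c2ccc(Cl)cc2n1S(=O)(=O)c1c(F)cccc1F` and compound 3 `Cc1ccc2[nH]c(=O)n(S(=O)(=O)c3c(F)cccc3F)c2c1` share a core; in an ADME assay on MT4 cells (Homo sapiens) for cytotoxicity (on this read-out lower numbers stand for higher toxicity in this test and higher numbers for lower toxicity in this test), compound 1 gives 194000 nM while compound 3 gives 2220 nM. The change between them is methyl in place of chloro on an aromatic carbon, and it brought an 87-fold lower number from compound 1 to compound 3 (1.94 log units; beyond the scatter). Compound 2 `O=c1[nH]c2ccc(Cl)cc2n1S(=O)(=O)c1cc(F)cc(F)c1` has the same atoms as compound 1 joined differently; the difference between the two cores is not broken down here. In this assay compound 2 gives 202000 nM, a value within the scatter of that of compound 1. Compound 4 `Cc1ccc2[nH]c(=O)n(S(=O)(=O)c3cc(F)cc(F)c3)c2c1` differs from compound 2 by methyl in place of chloro on an aromatic carbon, the same change as that from compound 1 to compound 3. Because an 87-fold lower number from compound 1 to compound 3 (1.94 log units; beyond the scatter) was large, a step of similar size is expected from compound 2 to compound 4, namely an 88-fold lower number from compound 2 to compound 4 (1.94 log units; beyond the scatter). Compound 4 is therefore estimated at 2300 nM, with a range from 800 nM to 7000 nM.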

Compound 4, half-maximal cytotoxic concentration: 23400 nM
Beside the measured number, compound 4's estimate is 10-fold (1.01 log units) below it, outside the stated range (above it).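

In this assay, methyl in place of chloro on an aromatic carbon again lowers the number, with an 8.6-fold lower number from compound 2 to compound 4 (0.94 log units; beyond the scatter), so the direction of the step carries over between the two cores. Its size does not carry over: the same change on two cores in this assay, an 87-fold lower number (1.94 log units; beyond the scatter) from compound 1 to compound 3 and an 8.6-fold lower number (0.94 log units; beyond the scatter) from compound 2 to compound 4, 10-fold (1.01 log units) apart, beyond the scatter of two such steps. These two pairs show only that the direction held on both cores and that the size differed; they do not show why the steps differ, or what the step would be on any further core.

The compounds shown leave open how an amine, a methoxy group or a carboxylic acid in the place of the chloro would read in this assay. They also leave open whether a bromo or an ethyl group would give steps as far apart on these two cores.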